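The compounds below may be only part of what the source reports. "The series", "measured", "known", "first", "only" and "open" are said of these compounds alone.

Measured so far:
Compound 1, `O=C(O)C[C@H](O)C[C@H](O)/C=C/c1c(C2CC2)nc2sccc2c1-c1ccc(F)cc1`, gives 38.1%.
Compound 2, `COc1ccc(-n2nc(C)c3c(-c4ccc(F)cc4)c(/C=C/[C@@H](O)C[C@@H](O)CC(=O)O)c(C(C)C)nc32)cc1`, gives -27.5%.

Both numbers come from an in vivo functional assay on the whole organism for inhibition of 3-hydroxy-3-methylglutaryl-coenzyme A reductase (Rattus norvegicus), at a dose of 0.2 mg/kg by the oral route; a lower number here means a weaker effect, a higher number a stronger effect of the compound at the dose given. Compound 2 stands lowest of the two; its nearest neighbour is compound 1, whose number lies higher by an amount beyond the usual scatter. The two compounds do not share a core, so the gap cannot be tied to any single part of the structure. Compound 3, `Cc1nn(C)c2nc(C(C)C)c(/C=C/[C@@H](O)C[C@@H](O)CC(=O)O)c(-c3ccc(F)cc3)c12`, shares the core of compound 2 and differs from it in one place: methyl in place of 4-methoxyphenyl on an aromatic nitrogen. The group that leaves carries one six-membered aromatic ring; the group that enters has no ring. For the measured compounds named here, no pair of measured compounds differing in one place exists here, so the effect of such a change has not been seen in these data. The negative number of compound 2 shows no inhibition at this dose, which leaves room for the number to move upward. The step from compound 2 to compound 3 is expected to be a number 37.5 percentage points higher from compound 2 to compound 3 (beyond the scatter), an increase, although it may well stay within the scatter. For compound 3 the estimate is 10%, within a range from -25% to 45%.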

Compound 3, a percentage reported as inhibition, in the whole organism at one dose (the size of the read-out at that dose, not a potency): 41.1%
Estimate against measurement, compound 3: 31.1 percentage points below; low and high end bracket the measured number.
By their numbers in this assay, from the lowest: compound 2; then compounds 1 and 3 (each within the scatter of the next).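

In this assay, with the rest of the structure unchanged, putting methyl in place of 4-methoxyphenyl on the aromatic nitrogen gives a number 68.6 percentage points higher from compound 2 to compound 3 (beyond the scatter). For the compounds shown here, this is the first change in a single place that can be read, and it shows that the group on this nitrogen can decide whether a compound has a clear effect at this one oral dose: the version with the small methyl group gives a clear inhibition, while the version with the six-membered aromatic ring gives none. Nothing available here explains the size of this step, so the result describes what happens to the read-out and not why it happens.

A single pair cannot show whether the ring itself or the methoxy group on it goes with the low number, or how the read-out changes with group size on this nitrogen. Plain phenyl, ethyl or a longer alkyl chain at the same place would help separate these possibilities, and a whole-animal number at one dose cannot by itself say at which stage between dosing and the enzyme the two compounds part ways.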